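This account rests on a few compounds, and the source may have more. Where it says the series, first, only, none or still open, it means among the compounds named here.

Compound 1 `O=C(Nc1ccccc1C(F)(F)F)C1CCc2ccccc2N1C(=O)c1ccccc1` is the starting point. Within the data shown here, in a functional assay on PC-3 cells (Homo sapiens) for cytotoxicity, read by sulforhodamine B assay, with a stated time of 72 h (a higher number here means a weaker inhibitor of growth, a lower number a stronger inhibitor of growth), compound 1 gives 5560 nM, the lowest of the three numbers measured so far. Its nearest neighbour is compound 2 `O=C(Nc1ccccc1O)C1CCc2ccccc2N1C(=O)c1ccccc1`, which in this assay gives 5690 nM; the step from one to the other is a 1.0-fold higher number from compound 1 to compound 2 (0.01 log units; within the scatter). Among the measured compounds shown here, the furthest is compound 3 `O=C(Nc1ccc(C(F)(F)F)cc1)C1CCc2ccccc2N1`, which in this assay gives 20300 nM, a clearly higher number; compound 3 differs from compound 1 in more than one place, so no single step is drawn between them.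

The compound still to be measured is compound 4 `CCCC(=O)N1c2ccccc2CCC1C(=O)Nc1ccccc1C(F)(F)F`. It differs from compound 1 in one place: propyl in place of phenyl on a carbonyl carbon. For the measured compounds named here, none of the measured steps touches this place. Going by the values given here, the only measured single step, between compound 1 and compound 2, swaps a group on an aromatic carbon and stays within the scatter, so it says nothing about the carbonyl carbon. Compound 3, which carries no benzoyl at all, gives a higher number, but other differences are mixed in, so it offers only a weak hint that losing the phenyl may weaken growth inhibition. The expected step is therefore modest and uncertain, leaning toward a higher number: a 1.4-fold higher number from compound 1 to compound 4 (0.16 log units; within the scatter) is the estimate. Compound 4 is expected to give about 8000 nM, within a range from 3000 nM to 25000 nM.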

Compound 4, concentration for 50% growth inhibition: > 70000 nM
Compound 4 ended at the assay's limit; the forecaster's own chance of this, stated with the estimate: 10%; middle value at least 8.7-fold (0.94 log units) away from the limit.
By their numbers in this assay, from the lowest: compounds 1 and 2 (each within the scatter of the next); then compound 3. At a limit, above all of these: compound 4.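

Until now, nothing had tested the group on this carbonyl carbon, and the answer is sharp: in this assay, replacing phenyl with propyl gives an at least 12-fold higher number from compound 1 to compound 4 (1.10 log units; beyond the scatter), while the swap on the aromatic carbon gave only a 1.0-fold higher number from compound 1 to compound 2 (0.01 log units; within the scatter). The phenyl of the benzoyl group therefore emerges as a sensitive feature of compound 1, and a simple propyl chain does not stand in for it in this assay without a large loss of growth inhibition. Compound 4 gives > 70000 nM, which is a limit of the assay and not a number, so the step shows only a minimum size and its true extent stays unknown: the limit of > 70000 nM in this assay, at which 1 of the 4 values shown sits.

This one change removes the aromatic ring and also reduces the group from 6 heavy atoms to 3, so the compounds shown cannot tell whether the ring itself or the size of the group counts. A cyclohexyl group on the same carbonyl carbon would keep a ring of similar size without the aromatic character, a longer chain such as hexyl would restore the size without any ring, and the two together could separate these readings.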